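Flipping One Stereocentre in Compound 3

A few compounds are considered here, and "the series" means these few. Any claim that something is new, unique, unknown or untested is made for them only; others in the source may bear on it.

In an ADME assay on microsomes from liver (Mus musculus) for metabolic stability, read by LC-MS, with a stated time of 10 min (a higher number here means that more of the compound is left, a lower number that less of the compound is left), compound 1 (`CN(C[C@H]1Cc2c(cccc2N2CCN(C3COC3)CC2)CN1)[C@H]1CCCc2cccnc21`) gives 50.8%, compound 2 (`CN(C[C@H]1Cc2c(cccc2N2CCNC(C)(C)C2)CN1)[C@H]1CCCc2cccnc21`) gives 44% and compound 3 (`CN(C[C@H]1Cc2c(cccc2N2CCN3CCC[C@H]3C2)CN1)[C@H]1CCCc2cccnc21`) gives 40.1%. Compound 3 therefore sits level with compound 2, as a number 3.9 percentage points lower from compound 2 to compound 3 (within the scatter) shows, and clearly under compound 1, as a number 10.7 percentage points lower from compound 1 to compound 3 (beyond the scatter) shows.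

Compound 4 (`CN(C[C@H]1Cc2c(cccc2N2CCN3CCC[C@@H]3C2)CN1)[C@H]1CCCc2cccnc21`) arises from compound 3 by a single change: the two compounds have the same atoms and bonds and differ only in configuration as drawn: 1 of 3 stereo elements differ; a stereocentre at a saturated ring carbon is drawn S in compound 3 and R in compound 4. Going by the values given here, no measured pair differs in this way alone, so the evidence is only indirect. The measured steps all swap a whole group on an aromatic carbon. Besides the two above, there is a number 6.8 percentage points lower from compound 1 to compound 2 (within the scatter). Among the compounds with values here, only the step from the oxetane-bearing compound 1 to compound 3 passes the scatter, and it is modest. Swapping whole groups thus gave small steps at most here, and nothing measured points to a direction for a change in configuration alone. In this assay, the expected step is a number 0.9 percentage points higher from compound 3 to compound 4 (within the scatter), which means none beyond the scatter. The estimate for compound 4 is 41%, with an expected range from 28% to 54%.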

Compound 4, percent of the compound remaining: 36.7%
For compound 4 the middle estimate is 4.3 percentage points above the measured one, and the stated range covers the measured number.
By their numbers in this assay, from the lowest: compounds 4, 3, 2 and 1 (each within the scatter of the next, the first and the last beyond it).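

In this assay, going by these compounds alone, a number 3.4 percentage points lower from compound 3 to compound 4 (within the scatter) shows that changing this saturated ring carbon from S to R leaves the result inside the usual scatter, the first reading for configuration alone, as every earlier step swapped a whole group. The comparison is a clean one on a single point: the fact that compounds 3 and 4 differ only in the configuration as drawn. The picture around the pair also holds for the R form, since a number 14.1 percentage points lower from compound 1 to compound 4 (beyond the scatter) shows the gap to the 4-(oxetan-3-yl)piperazin-1-yl compound still beyond the scatter, and a number 7.3 percentage points lower from compound 2 to compound 4 (within the scatter) shows compound 4 level with the 3,3-dimethylpiperazin-1-yl compound.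

Still open, going by these compounds, is whether a hydroxyl group or a fluorine atom on the five-membered ring would move the number in this assay. Also open, on these data alone, is whether the other two stereo elements would matter as little as this one.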